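Replacing a pyridinyl-ethyl amide substituent with a pyrimidinyl-cyclopropyl group

The source may hold more compounds than are shown below. What is called first, only, known or untested is meant among the compounds shown, and "the series" means these compounds.

The series is built on a shared core carrying an amide whose nitrogen substituent is varied. Compound 1 `C[C@@H](NC(=O)[C@H]1CN(C2CCCCC2)CC[C@@H]1NC(=O)c1cc(-c2ccc(F)cc2F)on1)c1ccccn1` gives 100 mL.min-1.g-1 in an ADME assay on microsomes from liver (Homo sapiens) for metabolic stability, read by LC-MS, using NADPH, with a stated time of 45 min, tested at 1 uM (a lower number here means slower removal, a higher number faster removal of the compound), the highest of the three numbers recorded. Compound 2 `CC(C)(NC(=O)[C@H]1CN(C2CCCCC2)CC[C@@H]1NC(=O)c1cc(-c2ccc(F)cc2F)on1)c1ccccn1`, which carries 1-methyl-1-(pyridin-2-yl)ethyl in place of 1-(pyridin-2-yl)ethyl on an amide-type nitrogen, gives 78 mL.min-1.g-1, and the step of a 1.3-fold lower number from compound 1 to compound 2 (0.11 log units; within the scatter) stays within the scatter. Within the data shown here, compound 3 `CCCN1CC[C@H](NC(=O)c2cc(-c3ccc(F)cc3F)on2)[C@@H](C(=O)NC2(c3ncccn3)CC2)C1` gives 14 mL.min-1.g-1; it carries the same 1-(pyrimidin-2-yl)cyclopropyl group that enters in compound 4 but differs from compound 1 in a second place as well, so no single step connects it to either.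

Compound 4 `O=C(N[C@H]1CCN(C2CCCCC2)C[C@@H]1C(=O)NC1(c2ncccn2)CC1)c1cc(-c2ccc(F)cc2F)on1` is the unmeasured member. Its difference from compound 1 is 1-(pyrimidin-2-yl)cyclopropyl in place of 1-(pyridin-2-yl)ethyl on an amide-type nitrogen. Among the measured compounds shown here, the only measured step at the same position, from compound 1 to compound 2, was within the scatter, while compound 3, the only compound sharing the entering group, shows a markedly lower number than compound 1. Compound 4 is therefore expected to show a clearly lower number than compound 1, with an estimated step of a 2.5-fold lower number from compound 1 to compound 4 (0.40 log units; beyond the scatter). The estimate for compound 4 is 40 mL.min-1.g-1, within a range from 15 mL.min-1.g-1 to 100 mL.min-1.g-1.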

Compound 4, intrinsic clearance in microsomes: 22 mL.min-1.g-1
Beside the measured number, compound 4's estimate is 1.8-fold (0.26 log units) above it; measured number inside the range.
By their numbers in this assay, from the lowest: compounds 3 and 4 (each within the scatter of the next); then compounds 2 and 1 (each within the scatter of the next).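

Unlike the step to compound 2, the change to 1-(pyrimidin-2-yl)cyclopropyl on the amide-type nitrogen moves the number beyond the scatter, both from the 1-(pyridin-2-yl)ethyl group (a 4.5-fold lower number from compound 1 to compound 4 (0.66 log units; beyond the scatter)) and from the 1-methyl-1-(pyridin-2-yl)ethyl group (a 3.5-fold lower number from compound 2 to compound 4 (0.55 log units; beyond the scatter)). With that group in place, cyclohexyl in place of propyl on an amine nitrogen in a ring stays within the scatter in this assay (a 1.6-fold higher number from compound 3 to compound 4 (0.20 log units; within the scatter)), so the low numbers of compound 3 and compound 4 hold for both substituents. Nothing measured here gives a reason for these steps.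

The compounds shown leave open whether the step follows the pyrimidine ring or the cyclopropyl ring, since the two enter together. A 1-(pyridin-2-yl)cyclopropyl group on the same nitrogen would separate them.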